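Swapping a Chlorophenyl for a Methoxyphenyl on the Amide

A few compounds are considered here, and "the series" means these few. Any claim that something is new, unique, unknown or untested is made for them only; others in the source may bear on it.

Compound 1 `O=C(Cn1cc(COc2ccc3c(c2)CCC3)nn1)Nc1ccc(Cl)cc1` carries an amide that links a 4-chlorophenyl group to the shared core. In an ADME assay on HEK293 cells (Homo sapiens) for inhibition, read by MTT assay, with a stated time of 48 h, tested at 25 uM (a lower number here means less inhibition, a higher number more inhibition at the concentration tested (going by the name of the read-out)), compound 1 gives "not determined" (no result reported), so no number anchors it. Its close relative compound 2 `COc1ccc(NC(=O)Cn2cc(COc3ccc4c(c3)CCC4)nn2)cc1` also gives "not determined" (no result reported) there. The only number among these compounds comes from compound 3 `COc1cccc(-n2cc(COc3ccc4c(c3)CCC4)nn2)c1`, which lacks the amide link and attaches its ring straight to the core; in this assay compound 3 gives 25.8%, a modest reading at the concentration tested.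

Compound 4 `COc1ccccc1NC(=O)Cn1cc(COc2ccc3c(c2)CCC3)nn1` differs from compound 1 in one place: 2-methoxyphenyl in place of 4-chlorophenyl on an amide-type nitrogen. For the measured compounds named here, with no number for compound 1, no measured step within this family can guide the direction, and nothing in the data suggests a shift beyond the usual scatter in this assay for such a change. Going by the values given here, compound 4 is therefore expected to land near the one available reading, at an estimated 25%, most likely between 8% and 45%.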

Compound 4, a percentage reported as inhibition, at one concentration (the size of the read-out at that concentration, not a potency): 23.4%
For compound 4 the middle estimate is 1.6 percentage points above the measured one; low and high end bracket the measured number.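

Compound 1 has no single number in this assay to set against compound 4, so no step can be read between them. As far as these compounds go, whether 2-methoxyphenyl in place of 4-chlorophenyl on the amide shifts this reading stays open. No supporting data here bear on the result.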